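Series notes: amidine analogues in mouse microsomal stability

A few compounds are considered here, and "the series" means these few. Any claim that something is new, unique, unknown or untested is made for them only; others in the source may bear on it.

Measured so far:
compound 1 `CCN(CC)CCCCN/C(=N\c1ccnc2cc(Cl)ccc12)C(C)C` — 0.7 h
compound 2 `CN(C)CCC/N=C(\c1ccccc1)N(CCCN(C)C)c1ccnc2cc(Cl)ccc12` — > 1 h
compound 3 `CN(C)CCCN/C(=N\c1ccnc2cc(Cl)ccc12)c1ccc(Cl)cc1` — 0.583 h

In an ADME assay (liver, Mus musculus) for metabolic stability, read by LC-MS, using microsomes, tested at 1 uM (a higher number here means that the compound lasts longer, a lower number that the compound disappears faster), compound 1 gives 0.7 h, the higher of the two numbers reported. Compound 3 gives 0.583 h in this assay, which sits within the scatter of compound 1, so no order between the two can be drawn. The value for compound 2 in this assay is a limit, not a number (the limit of > 1 h in this assay, at which 1 of the 3 values shown sits).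

Compound 4 `CC(C)/C(=N/c1ccnc2cc(Cl)ccc12)NCCCCN1CCCCC1` has not yet been measured in this assay. It differs from compound 1 in one place: piperidin-1-yl in place of diethylamino on a saturated chain carbon, four bonds along the chain from an amine nitrogen. The change exchanges one amine terminus for another on the saturated chain, the carbon count shifting by one, with the hydrogen-bond acceptor count unchanged.

Within the data shown here, no measured pair isolates a change of this kind, so there is no basis for expecting a step beyond the scatter in either direction. Compound 4 is therefore expected to fall close to compound 1, the step of no change at the digits printed from compound 1 to compound 4 (within the scatter) being within the usual scatter. The expected half-life for compound 4 in this assay is 0.7 h, with a range from 0.35 h to 1.4 h.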

Compound 4, half-life: 0.517 h
For compound 4 the middle estimate is 1.4-fold (0.13 log units) above the measured one; the measured number falls inside the stated range.
By their numbers in this assay, from the lowest: compounds 4, 3 and 1 (each within the scatter of the next). At a limit, above all of these: compound 2.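

In this assay, among these compounds, this is the first pair that differs in one place, and it gives a 1.4-fold lower number from compound 1 to compound 4 (0.13 log units; within the scatter). Piperidin-1-yl in place of diethylamino on a saturated chain carbon, four bonds along the chain from an amine nitrogen, therefore does not separate the two compounds, and on this chain a six-membered non-aromatic ring at the amine terminus reads the same as the open diethylamino group. Nothing measured here speaks to the reason for this result.

Still open, as far as these compounds go, is whether a morpholine ring or a primary amine at the end of this chain would give a step beyond the scatter. Also open, from the compounds shown here alone, is whether the same exchange would read alike on the rest of compound 3, which differs from compound 1 in more than one place.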